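The compounds below may be only part of what the source reports. "The series", "measured", "known", "first", "only" and "open" are said of these compounds alone.

Three compounds sharing one core and differing only in the group on the amide carbonyl carbon have been measured. Compound 1 `CN1[C@@H]2c3[nH]c4ccccc4c3C[C@H]1[C@H](C#N)N1[C@@H](CNC(=O)c3cccc(C(F)(F)F)c3)c3[nH]c4ccccc4c3C[C@@H]21` gives 210 nM in a functional assay on A2780 cells (Homo sapiens) for cytotoxicity, read by MTT assay, with a stated time of 72 h; on this read-out lower numbers stand for stronger inhibition and higher numbers for weaker inhibition. Compound 2 `CN1[C@@H]2c3[nH]c4ccccc4c3C[C@H]1[C@H](C#N)N1[C@@H](CNC(=O)c3ccc(Cl)cc3)c3[nH]c4ccccc4c3C[C@@H]21` gives 230 nM. Compound 3 `CCc1ccc(C(=O)NC[C@H]2c3[nH]c4ccccc4c3C[C@H]3[C@H]4c5[nH]c6ccccc6c5C[C@@H]([C@H](C#N)N23)N4C)cc1` gives 670 nM, the highest number of the three: the steps of a 3.2-fold higher number from compound 1 to compound 3 (0.50 log units; beyond the scatter) and a 2.9-fold higher number from compound 2 to compound 3 (0.46 log units; beyond the scatter) both lie beyond the scatter, while a 1.1-fold higher number from compound 1 to compound 2 (0.04 log units; within the scatter) does not. Compound 4 `CN1[C@@H]2c3[nH]c4ccccc4c3C[C@H]1[C@H](C#N)N1[C@@H](CNC(=O)/C=C/c3ccccc3)c3[nH]c4ccccc4c3C[C@@H]21` differs from compound 3 by 2-phenylethenyl in place of 4-ethylphenyl on a carbonyl carbon. Within the data shown here, no measured step touches the 2-phenylethenyl group; the measured steps only show that swapping the group on this carbonyl carbon moves the number modestly, in either direction. Compound 4 is therefore estimated at 400 nM, with a range from 150 nM to 1100 nM. That estimate corresponds to an expected step of a 1.7-fold lower number from compound 3 to compound 4 (0.22 log units; within the scatter).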

Compound 4, half-maximal inhibitory concentration: 770 nM
Compound 4: middle estimate off by 1.9-fold (0.28 log units), on the low side, within the range that was stated.
By their numbers in this assay, from the lowest: compounds 1 and 2 (each within the scatter of the next); then compounds 3 and 4 (each within the scatter of the next).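

Swapping 4-ethylphenyl for 2-phenylethenyl, which brings a double bond outside the aromatic ring, changes little, with a 1.1-fold higher number from compound 3 to compound 4 (0.06 log units; within the scatter). Compound 4 still sits apart from the other two, with a 3.3-fold higher number from compound 2 to compound 4 (0.52 log units; beyond the scatter) and a 3.7-fold higher number from compound 1 to compound 4 (0.56 log units; beyond the scatter), so compounds 3 and 4 form a higher-number pair against compounds 1 and 2. Nothing available explains why these groups fall into two pairs. Every group shown on this carbonyl carbon carries a six-membered aromatic ring of carbon only. On these data alone, what a plain hexyl chain or a group bearing an amine would do there remains open.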